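Changing the Halogenated Aryl Group in Compound 3

This account rests on a few compounds, and the source may have more. Where it says the series, first, only, none or still open, it means among the compounds named here.

Compound 1, `COc1ccc(/C=C2\C(=O)N(c3c(Cl)cccc3Cl)c3ccccc32)cc1`, gives in a functional assay on HuTu80 cells (Homo sapiens) for cytotoxicity, read by MTT assay, with a stated time of 72 h (on this read-out higher numbers stand for an effect only at larger amounts of compound and lower numbers for an effect already at smaller amounts), only a limit, > 100 ug/mL.
Compound 2, `O=C1/C(=C\c2cccc(Br)c2)c2ccccc2N1c1c(Cl)cccc1Cl`, gives in this assay a value of 7 ug/mL.

Among the compounds with values here, compound 2 stands as the only compound here with a true number; the other result is a limit of the assay. Within the data shown here, the single measured step, an at least 14-fold lower number from compound 1 to compound 2 (1.15 log units; beyond the scatter), shows that exchanging the aryl group on the chain carbon can move the read-out strongly, with compound 1 sitting at the limit (the limit of > 100 ug/mL in this assay, at which 1 of the 2 values shown sits). Compound 3, `O=C1/C(=C\c2ccccc2Cl)c2ccccc2N1c1c(Cl)cccc1Cl`, differs from compound 2 by 2-chlorophenyl in place of 3-bromophenyl on a double-bonded chain carbon bound to a double-bonded ring carbon. Among the measured compounds shown here, that measured step is the only one bearing on this change, and it concerns the same place, but it compares a methoxy-bearing ring with a halogen-bearing one, whereas compound 2 and compound 3 both carry a halogen on the ring. The guidance is therefore indirect. The expected step is a 1.4-fold higher number from compound 2 to compound 3 (0.15 log units; within the scatter), that is, no change beyond the scatter or at most a modest weakening. Compound 3 is thus estimated to give about 10 ug/mL, within a range from 3 ug/mL to 40 ug/mL.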

Compound 3, concentration for half-maximal effect: > 100 ug/mL
Compound 3 was reported as a limit; the forecaster's own chance of this, stated with the estimate: 20%; at least 10-fold (1.00 log units) between middle value and limit.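

Exchanging one halogen-bearing ring for another on a double-bonded chain carbon bound to a double-bonded ring carbon has a strong effect in this assay: putting 2-chlorophenyl in place of 3-bromophenyl gives an at least 14-fold higher number from compound 2 to compound 3 (1.15 log units; beyond the scatter), although the two groups match in heavy atoms, hydrogen-bond donors, hydrogen-bond acceptors and charge. Compound 1 and compound 2 alone left room to think that any halogen on this ring might be enough, but compound 3 rules that out, and among the three compounds shown only the 3-bromophenyl group gives a true number. The step between compound 1 and compound 3 cannot be read, as both results are limits of the assay and not numbers: the limit of > 100 ug/mL in this assay, at which 2 of the 3 values shown sit.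

This change alters both the halogen and its number in the group's name, so the compounds shown cannot tell which of the two matters. A 3-chlorophenyl or a 2-bromophenyl group would separate the two, and a ring carrying an amine or a carboxylic acid would test whether anything other than a halogen can give a measurable value here.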